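From Compound 2 to Compound 3: Exchanging the Fused Ring

This account rests on a few compounds, and the source may have more. Where it says the series, first, only, none or still open, it means among the compounds named here.

Of the compounds shown here, two have been tested in a functional assay on MCF7 cells (Homo sapiens) for cytotoxicity, read by CellTiter-Glo, with a stated time of 5 days; on this read-out lower numbers stand for stronger inhibition and higher numbers for weaker inhibition. Compound 1 `O=C(O)/C=C/c1ccc(/C(=C(/CCF)c2ccccc2)c2ccc3[nH]ncc3c2)cc1` gives 2.1 nM in this assay. Compound 2 `CC/C(=C(/c1ccc(/C=C/C(=O)O)cc1)c1cnc2[nH]ncc2c1)c1ccccc1` gives 302 nM in this assay, the higher of the two numbers, and the gap between these two values lies well beyond the usual scatter of such measurements.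

Compound 3 `CC/C(=C(/c1ccc(/C=C/C(=O)O)cc1)c1cc(Cl)c2[nH]ncc2c1)c1ccccc1` has not yet been measured. It differs from compound 2 in one place: a group of 10 heavy atoms (7 carbon, 2 nitrogen, 1 chlorine; one five-membered aromatic ring with 2 hetero atoms, one six-membered aromatic ring of carbon only) in place of a group of 9 heavy atoms (6 carbon, 3 nitrogen; one five-membered aromatic ring with 2 hetero atoms, one six-membered aromatic ring with 1 hetero atom), on a double-bonded chain carbon bound to an aromatic carbon and a double-bonded chain carbon. The group that enters in compound 3 resembles the corresponding part of compound 1, whose number in this assay is far lower than that of compound 2; the two compounds also differ elsewhere, so the comparison is not clean.

Compound 3 is nevertheless expected to move strongly toward a lower number in this assay, with the estimated step of a 20-fold lower number from compound 2 to compound 3 (1.30 log units; beyond the scatter). For compound 3 the estimate is 15 nM, with a likely range from 3 nM to 80 nM.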

Compound 3, half-maximal inhibitory concentration: 56 nM
Compound 3: middle estimate off by 3.7-fold (0.57 log units), on the low side; the measured number falls inside the stated range.
By their numbers in this assay, from the lowest: compound 1; then compound 3; then compound 2.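

In this assay, the exchange of the group on the double-bonded chain carbon gives a 5.4-fold lower number from compound 2 to compound 3 (0.73 log units; beyond the scatter), so this place on the shared core responds measurably to the identity of the fused ring group, which compounds 1 and 2 could not show on their own because they differ in more than one place. Going by these compounds alone, the change is a double one: 7-chloro-1H-indazol-5-yl brings a chlorine and also a six-membered aromatic ring of carbon only, in place of a six-membered aromatic ring with 1 hetero atom, and the single step reports only the sum of these two differences. No measurement is at hand that bears on why this exchange lowers the number.

How much of the step belongs to the chlorine and how much to the loss of the ring nitrogen stays open, since the compounds shown include no pair that separates the two. Also open, on these data alone, is how a methyl group or a nitrile in place of the chlorine would stand at this place on the same core.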